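The compounds below may be only part of what the source reports. "The series", "measured", "known", "first", "only" and "open" are said of these compounds alone.

Measured in an assay on microsomes from liver for inhibition of sterol O-acyltransferase 1 (Rattus norvegicus); a lower number here means a stronger inhibitor, a higher number a weaker inhibitor:
compound 1 `Cn1c(SC[C@H]2C[C@@](C)(O)CC(=O)O2)nc(-c2ccccc2)c1-c1ccccc1.Cn1c(SC[C@H]2C[C@](C)(O)CC(=O)O2)nc(-c2ccccc2)c1-c1ccccc1`, for which compound 1 gives 2600 nM
compound 2 `O=C1CCCC(CSc2nc(-c3ccccc3)c(-c3ccccc3)[nH]2)O1`, for which compound 2 gives 740 nM
compound 3 `Clc1cccc(-c2[nH]c(SCC3CCCCO3)nc2-c2ccccc2)c1`, for which compound 3 gives 560 nM

Compound 2 holds the second highest of the three numbers. Compound 3 lies nearest, its number lower by a margin within the usual scatter, so no order between compound 2 and compound 3 is read. Compound 1 stands furthest, with a number beyond the scatter above that of compound 2.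

Compound 4 `c1ccc(-c2nc(SCC3OCCO3)[nH]c2-c2ccccc2)cc1` has not been measured in this assay. Relative to compound 2 it carries a group of 5 heavy atoms (3 carbon, 2 oxygen; one five-membered non-aromatic ring with 2 hetero atoms) in place of a group of 7 heavy atoms (5 carbon, 2 oxygen; one six-membered non-aromatic ring with 1 hetero atom), on a saturated chain carbon bound to a sulfur. For the measured compounds named here, no pair of measured compounds differs in one place, so this change has no precedent. With compound 2 at 740 nM and compound 3 within scatter of it, little movement beyond the scatter is expected, if anything a modest weakening. The step from compound 2 to compound 4 is expected to be a 1.4-fold higher number from compound 2 to compound 4 (0.13 log units; within the scatter). For compound 4 the estimate in this assay is 1000 nM, within 350 nM to 3000 nM.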

Compound 4, half-maximal inhibitory concentration: 530 nM
The estimate for compound 4 lay 1.9-fold (0.28 log units) above the measured number; low and high end bracket the measured number.
By their numbers in this assay, from the lowest: compounds 4, 3 and 2 (each within the scatter of the next); then compound 1.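

On the saturated chain carbon bound to a sulfur, 1,3-dioxolan-2-yl replaces the group with one six-membered non-aromatic ring with 1 hetero atom, and this assay shows a 1.4-fold lower number from compound 2 to compound 4 (0.14 log units; within the scatter); no order is read, and this place accepts the smaller ring without a change beyond the scatter. Both groups count 0 hydrogen-bond donors and 2 hydrogen-bond acceptors, while the double bond outside aromatic rings is lost in compound 4. No supporting data explain this result. Open, from the compounds shown here alone, is whether an amine, a carboxylic acid or a longer chain at this place would shift the number beyond the scatter.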